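The source may hold more compounds than are shown below. What is called first, only, known or untested is meant among the compounds shown, and "the series" means these compounds.

Two compounds of one shared core have numbers in a functional assay on cells for antagonist activity at C-C chemokine receptor type 4 (Homo sapiens), read by fluorescence and calcium flux, with stated times of 2.5 s and 45 s; on this read-out higher numbers stand for weaker inhibition and lower numbers for stronger inhibition. Compound 1 `CC1CN(c2cnc3cnn(C(C)c4ccc(Cl)cc4Cl)c3n2)CCC1N1CCCCC1` carries a piperidin-1-yl group on the saturated ring and in this assay compound 1 gives 238 nM. Compound 2 `Cc1nn([C@H](C)c2ccc(Cl)cc2Cl)c2nc(N3CC[C@H](N4CCCCCC4)[C@H](C)C3)cnc12` carries an azepan-1-yl group in the same position and in this assay compound 2 gives 23 nM. Among the two numbers compound 2 stands at the lower one, and its gap to compound 1 lies beyond the usual scatter, so compound 2 is the stronger inhibitor of the pair.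

Compound 3 `Cc1nn([C@H](C)c2ccc(Cl)cc2Cl)c2nc(N3CC[C@H](N4CCC[C@H]4CCC(N)=O)[C@H](C)C3)cnc12` has not been measured in this assay. It differs from compound 2 in one place (2-(2-carbamoylethyl)pyrrolidin-1-yl in place of azepan-1-yl on a saturated ring carbon). No step between two measured compounds of this series addresses such a change, so the step can only be guessed from the two numbers shown. Some loss of inhibition is expected, but of modest size, so that the estimated step of a 2.0-fold higher number from compound 2 to compound 3 (0.29 log units; within the scatter) stays close to the scatter. For compound 3 the estimated value in this assay is 45 nM, with a range from 12 nM to 170 nM.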

Compound 3, half-maximal inhibitory concentration: 37 nM
Compound 3: middle estimate off by 1.2-fold (0.09 log units), on the high side; measured number inside the range.
By their numbers in this assay, from the lowest: compounds 2 and 3 (each within the scatter of the next); then compound 1.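

In this assay, swapping the azepan-1-yl group for a 2-(2-carbamoylethyl)pyrrolidin-1-yl group, next to the ring atom that bears a methyl group, gives a 1.6-fold higher number from compound 2 to compound 3 (0.21 log units; within the scatter), so the read-out does not separate the two compounds. This is the only pair shown that differs in one place, and it indicates that this position tolerates a substantial change in the group it carries: 10 heavy atoms replace 7, a five-membered ring replaces a seven-membered one, and 1 hydrogen-bond donor replaces none, with no difference beyond the scatter. No supporting measurement is available to explain why the two groups give such similar numbers.

The compounds shown leave open whether the carbamoylethyl chain contributes at all, as plain pyrrolidin-1-yl, or a version with a carboxylic acid or a primary amine in place of the amide, would test this. They also leave open how a longer chain, or the opposite configuration at the defined stereocentre of the pyrrolidine ring, would read in this assay.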